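The source may report more compounds than this note shows. Statements on the series, on what has been measured and on what is new or still open speak of the compounds shown alone.

Compound 1 `N#Cc1cccc(COc2ccc(-c3cc(CN4CCN(c5ccc(C(F)(F)F)cn5)CC4)no3)cc2)c1` and compound 2 `N#Cc1cccc(COc2ccc(-c3cc(CN4CCN(Cc5ccccc5F)CC4)no3)cc2)c1` share a core and differ only at the ring nitrogen of the six-membered non-aromatic ring. In a functional assay on MCF7 cells (Homo sapiens) for antiproliferative activity, read by sulforhodamine B assay, with a stated time of 72 h (a higher number here means a weaker inhibitor, a lower number a stronger inhibitor), compound 1 gives 1400 nM, and compound 2 gives 1400 nM, so that compound 2 stands level with compound 1, the step of no change at the digits printed from compound 1 to compound 2 (within the scatter) lying within the scatter. Compound 3 `CC(C)(C)OC(=O)N1CCN(Cc2cc(-c3ccc(OCc4cccc(C#N)c4)cc3)on2)CC1` is not yet measured; its difference from compound 2 is tert-butoxycarbonyl in place of 2-fluorobenzyl on an amine nitrogen in a ring. Going by the values given here, only the step from compound 1 to compound 2 bears on this place, and it showed no change, but it exchanged one aromatic group for another, whereas tert-butoxycarbonyl brings no ring and two hydrogen-bond acceptors. Among the compounds with values here, the one measured step therefore gives little warning of a large move, and the expected step of a 1.4-fold higher number from compound 2 to compound 3 (0.15 log units; within the scatter) is small, if anything toward weaker inhibition. Compound 3 is estimated at 2000 nM in this assay, with a range from 700 nM to 6000 nM.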

Compound 3, half-maximal inhibitory concentration: 3800 nM
Compound 3: the middle estimate sits 1.9-fold (0.28 log units) below what was measured; low and high end bracket the measured number.
By their numbers in this assay, from the lowest: compounds 1 and 2 (each within the scatter of the next); then compound 3.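

The ring nitrogen is not indifferent to what it carries. In this assay, the change to tert-butoxycarbonyl gives a 2.7-fold higher number from compound 2 to compound 3 (0.43 log units; beyond the scatter) when it replaces 2-fluorobenzyl and a 2.7-fold higher number from compound 1 to compound 3 (0.43 log units; beyond the scatter) when it replaces 5-(trifluoromethyl)pyridin-2-yl. Compounds 1 and 2, each with an aromatic ring in this group, stand level, so the first modest move toward weaker inhibition at this position appears with a group that has no ring and does have a carbonyl; no measurement shown explains this move.

Because the ring leaves as the carbonyl enters in a single change, the compounds shown do not separate the two. Going by these compounds, it remains open how a cyclohexylmethyl group, an acetyl group or a bare secondary amine on that nitrogen would read in this assay.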